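From an amide back to an ester on the shared core

A few compounds are considered here, and "the series" means these few. Any claim that something is new, unique, unknown or untested is made for them only; others in the source may bear on it.

Of the compounds shown here, two on the shared core have been measured in an assay on membranes from HeLa cells for displacement of a labelled ligand from adenosine receptor A3 (Homo sapiens), read by scintillation counting, with a stated time of 180 min, tested at 1 uM; a lower number here means less inhibition, a higher number more inhibition at the concentration tested (going by the name of the read-out). Compound 1 `CC1=C(C(=O)OCC(C)C)C(c2ccoc2)NC(=O)N1` gives 16% in this assay, and compound 2 `CC1=C(C(=O)NC(C)C)C(c2ccoc2)NC(=O)N1` gives 3%. Among the measured compounds shown here, compound 2 thus stands lowest of the two numbers, its nearest neighbour being compound 1, and the one measured step, a number 13 percentage points lower from compound 1 to compound 2 (beyond the scatter), runs downward when isopropylamino replaces isobutoxy on the carbonyl carbon.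

Compound 3 `CCC(CC)OC(=O)C1=C(C)NC(=O)NC1c1ccoc1` is the next compound to be read in this assay. Its difference from compound 2 is (pentan-3-yl)oxy in place of isopropylamino on a carbonyl carbon. For the measured compounds named here, this change bears directly on the single measured step: it undoes the move to the amide and restores an ester on the carbonyl carbon, now with a pentan-3-yl group rather than isobutyl. Since the step of a number 13 percentage points lower from compound 1 to compound 2 (beyond the scatter) was modest but beyond the scatter, the reverse move is expected to carry compound 3 upward by about as much, with the step estimated as a number 14 percentage points higher from compound 2 to compound 3 (beyond the scatter). Compound 3 is therefore expected to give about 17% in this assay, within a range from 5% to 30%.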

Compound 3, a percentage reported as inhibition, at one concentration (the size of the read-out at that concentration, not a potency): 5%
Compound 3: the middle estimate sits 12 percentage points above what was measured, within the range that was stated.
By their numbers in this assay, from the lowest: compounds 2 and 3 (each within the scatter of the next); then compound 1.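

With (pentan-3-yl)oxy in place of isopropylamino on the carbonyl carbon, the step is a number 2 percentage points higher from compound 2 to compound 3 (within the scatter), so in this assay an ester at this place does not by itself go with the number seen for compound 1. Among the compounds shown here, the comparison between the two esters, pentan-3-yl in place of isobutyl on an oxygen next to a carbonyl group, gives a number 11 percentage points lower from compound 1 to compound 3 (beyond the scatter); the earlier compounds could not show this, as they differed only by exchanging an ester for an amide, and here the group carried on the ester oxygen is what changes. No supporting measurement accounts for either step.

On these data alone, what remains open is how the read-out would respond to other groups on the carbonyl carbon, such as a methoxy or ethoxy ester, a carboxylic acid or an amide of a longer amine. The three compounds also leave open whether any of these differences would persist as a difference in potency, since each number is a reading at a single concentration and all three compounds share the same remaining core.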